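Phenoxy for Methylsulfanyl: Expected Effect on Channel Inhibition

The source may hold more compounds than are shown below. What is called first, only, known or untested is meant among the compounds shown, and "the series" means these compounds.

Of the compounds shown here, two sharing one core have been measured in an assay for inhibition of acid-sensing ion channel 3 (Homo sapiens), read by patch clamp, tested at 1 uM; a higher number here means more inhibition at the concentration tested (going by the name of the read-out), a lower number less inhibition. Compound 1, `NC(N)=NC(=O)c1nc(Cl)c(NC2CCCCC2)nc1N`, carries a cyclohexylamino group and gives 21%. Compound 2, `CSc1nc(N)c(C(=O)N=C(N)N)nc1Cl`, carries methylsulfanyl at the same position and gives 12%. Among the compounds with values here, the step of a number 9 percentage points lower from compound 1 to compound 2 (within the scatter) lies within the scatter, so the two numbers cannot be told apart, and compound 2 stands at the same level as its only neighbour.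

Compound 3, `NC(N)=NC(=O)c1nc(Cl)c(Oc2ccccc2)nc1N`, is the next variation at that position: phenoxy in place of methylsulfanyl on an aromatic carbon. Within the data shown here, the one measured step that bears on this, the exchange at the same carbon a number 9 percentage points lower from compound 1 to compound 2 (within the scatter), was within the scatter, and no other comparison exists. Among the measured compounds shown here, on that basis no step beyond the scatter is expected in this assay, in either direction, though the single comparison is thin ground. Compound 3 is therefore estimated at 16%, with a range of 0% to 36%, which means an expected step of a number 4 percentage points higher from compound 2 to compound 3 (within the scatter).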

Compound 3, a percentage reported as inhibition, at one concentration (the size of the read-out at that concentration, not a potency): 23%
Estimate against measurement, compound 3: 7 percentage points below; low and high end bracket the measured number.
By their numbers in this assay, from the lowest: compounds 2, 1 and 3 (each within the scatter of the next, the first and the last beyond it).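

In this assay, within the data shown here, the exchange of methylsulfanyl for phenoxy gives a number 11 percentage points higher from compound 2 to compound 3 (beyond the scatter) and so provides the first sign that the group on this aromatic carbon can move the read-out beyond the scatter, though only modestly. The exchange of cyclohexylamino for phenoxy gives a number 2 percentage points higher from compound 1 to compound 3 (within the scatter) and leaves these two groups indistinguishable here, while compound 1 itself remains within the scatter of compound 2, so the three compounds do not fall into separate levels and only compound 2 and compound 3 can be told apart. Nothing at hand accounts for the step from methylsulfanyl to phenoxy, which stands as an observation without an explanation.

The compounds shown leave open whether the aromatic ring of phenoxy matters or whether the linking oxygen does, a question that phenylamino, benzyloxy or methoxy at the same carbon could address. They also leave open whether any group here can carry inhibition well beyond the modest level seen so far, and whether the chloro and amino groups on the shared core contribute to it.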